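From Sulfonamide to Amide on a Shared Core

The compounds below may be only part of what the source reports. "The series", "measured", "known", "first", "only" and "open" are said of these compounds alone.

Measured so far in a functional assay on SK-MEL-28 cells (Homo sapiens) for cytotoxicity, read by MTT assay; on this read-out lower numbers stand for stronger inhibition and higher numbers for weaker inhibition:
- compound 1, `O=S(=O)(NCCNc1nccc(-c2c(-c3cccc(F)c3)nc3sccn23)n1)c1ccc(Br)cc1`: 13500 nM
- compound 2, `O=S(=O)(NCCNc1nccc(-c2c(-c3cccc(F)c3)nc3sccn23)n1)c1cccc(F)c1`: 18300 nM
- compound 3, `O=S(=O)(NCCNc1nccc(-c2c(-c3cccc(F)c3)nc3sccn23)n1)c1ccccc1`: 19000 nM

Compound 3 gives the highest of the three numbers, but all three sit within the scatter of one another: the step of a 1.4-fold higher number from compound 1 to compound 3 (0.15 log units; within the scatter) and the step of a 1.0-fold higher number from compound 2 to compound 3 (0.02 log units; within the scatter) are both within the scatter, as is a 1.4-fold higher number from compound 1 to compound 2 (0.13 log units; within the scatter). None of these compounds can therefore be called stronger or weaker than another in this assay.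

Compound 4, `Cc1ccc(C(=O)NCCNc2nccc(-c3c(-c4cccc(F)c4)nc4sccn34)n2)cc1`, has not yet been measured. It differs from compound 3 by (4-methylphenyl)carbonyl in place of phenylsulfonyl on an amine nitrogen. Within the data shown here, every measured step so far changes only a substituent on the ring attached to the sulfonyl sulfur; none exchanges the phenylsulfonyl group itself for a (4-methylphenyl)carbonyl group, so no measured step bears directly on this change. In the absence of such a step, the expectation is that compound 4 stays near the range of the measured compounds, with a wide uncertainty in either direction: the expected step is a 1.3-fold lower number from compound 3 to compound 4 (0.10 log units; within the scatter). Compound 4 is thus estimated at 15000 nM in this assay, within a range from 5000 nM to 45000 nM.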

Compound 4, half-maximal inhibitory concentration: 18800 nM
For compound 4 the middle estimate is 1.3-fold (0.10 log units) below the measured one, within the range that was stated.
By their numbers in this assay, from the lowest: compounds 1, 2, 4 and 3 (each within the scatter of the next).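

Exchanging phenylsulfonyl for (4-methylphenyl)carbonyl on the amine nitrogen replaces the sulfonyl with a carbonyl and brings in a methyl group, yet in this assay the result stays within the scatter: a 1.0-fold lower number from compound 3 to compound 4 (0.00 log units; within the scatter). The comparisons with the two sulfonyl compounds carrying a ring substituent also stay within the scatter, with a 1.0-fold higher number from compound 2 to compound 4 (0.01 log units; within the scatter) and a 1.4-fold higher number from compound 1 to compound 4 (0.14 log units; within the scatter), so among these four compounds, this position accepts either a sulfonyl or a carbonyl link without a step beyond the scatter. No measurement is available that would explain this result.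

Compound 4 carries the new carbonyl and the methyl group together, so the contribution of each cannot be separated. Going by these compounds, how a phenylcarbonyl group without the methyl, or a ring bearing an amine or a carboxylic acid, would behave at this position remains open.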